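This account rests on a few compounds, and the source may have more. Where it says the series, first, only, none or still open, it means among the compounds named here.

Compound 1 `Cc1ccc(-n2c(-c3coc4cc(C)c(Cl)cc4c3=O)nc(-c3ccccc3)c2-c2ccccc2)c(C)c1` gives 6250 nM
Compound 2 `Cc1cc2occ(-c3nc(-c4ccccc4)c(-c4ccccc4)n3-c3ccc(Cl)cc3)c(=O)c2cc1Cl` gives 12500 nM

Both values come from a functional assay on A549 cells (Homo sapiens) for inhibition, read by MTT assay, with a stated time of 72 h (on this read-out higher numbers stand for weaker inhibition and lower numbers for stronger inhibition), and are all that is known so far. Within the data shown here, with only two numbers, compound 2 has a single neighbour, compound 1, and the two lie within the usual scatter of each other.

Compound 3 `Cc1ccc(-n2c(-c3coc4cc(C)c(Cl)cc4c3=O)nc(-c3ccccc3)c2-c2ccccc2)cc1` has not yet been measured. It differs from compound 2 by methyl in place of chloro on an aromatic carbon, para to a large group (methyl in place of chloro on an aromatic carbon). The same difference, seen one bond further out, turns 4-chlorophenyl into 4-methylphenyl.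

Among the measured compounds shown here, one measured step bears on this change (a 2.0-fold higher number from compound 1 to compound 2 (0.30 log units; within the scatter)). It also alters the group on the aromatic nitrogen, and it stays within the scatter. That single step gives no ground to expect a real shift in this assay in either direction. The expected change is small (a 1.4-fold lower number from compound 2 to compound 3 (0.14 log units; within the scatter)) and would not go beyond the scatter. The estimated value for compound 3 is 9000 nM (expected range 3500 nM to 23000 nM).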

Compound 3, half-maximal inhibitory concentration: 12500 nM
Compound 3: middle estimate off by 1.4-fold (0.14 log units), on the low side; low and high end bracket the measured number.
By their numbers in this assay, from the lowest: compounds 1, 2 and 3 (each within the scatter of the next).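

With the rest of the molecule unchanged, 4-methylphenyl in place of 4-chlorophenyl on the aromatic nitrogen gives no change at the digits printed from compound 2 to compound 3 (within the scatter) in this assay, so chloro and methyl at this place, para to a large group, cannot be told apart on this read-out. Going from 2,4-dimethylphenyl to 4-methylphenyl, with hydrogen in place of methyl on an aromatic carbon, gives a 2.0-fold higher number from compound 1 to compound 3 (0.30 log units; within the scatter), which splits the earlier comparison, where two places differed at once, into two single changes that both stay within the scatter. Nothing measured here offers an explanation for these results.

The compounds shown hold only chloro and methyl at this place, so it remains open whether an amine, a carboxylic acid or a longer chain such as butyl there would move the number beyond the scatter. Also open, on these data alone, is what a change elsewhere would do, for example an amine in place of either phenyl group on the shared core, or a replacement for the chloro or methyl on the core itself.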